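The compounds below may be only part of what the source reports. "The series", "measured", "known", "first", "only" and "open" are said of these compounds alone.

Measured compounds:
- compound 1 `CCC1(Cc2ccccc2)OS(=O)(=O)C=C1OC`: > 200000 nM
- compound 2 `CCC1(Cc2ccccc2)OS(=O)(=O)C=C1OCc1ccc(Cl)c(Cl)c1`: 36700 nM
- compound 3 `CCC1(Cc2ccccc2)OS(=O)(=O)C=C1OCc1ccc(C(F)(F)F)cc1`: 99000 nM

All three values come from an ADME assay on HEL cells (Homo sapiens) for cytotoxicity, with a stated time of 3 days; a higher number here means that more compound is tolerated, a lower number that less compound is tolerated. For compound 1 the value > 200000 nM is a limit of the assay rather than a number, so compound 1 sits at the limit of > 200000 nM in this assay, at which 1 of the 3 values shown sits, and its true tolerated concentration is not pinned down. Compound 2 and compound 3 each replace the methyl on the oxygen with a group carrying a substituted aromatic ring, and each gives a number rather than a limit. The step of an at least 5.4-fold lower number from compound 1 to compound 2 (0.73 log units; beyond the scatter) shows that such an addition lowered the tolerated concentration in that assay.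

Compound 4 `CCC1(Cc2ccccc2)OS(=O)(=O)C=C1OC(=O)c1ccccc1` has not yet been measured. It differs from compound 1 by benzoyl in place of methyl on an oxygen on an unsaturated carbon. For the measured compounds named here, the one measured step that bears on this change is an at least 5.4-fold lower number from compound 1 to compound 2 (0.73 log units; beyond the scatter), where an aromatic ring also entered at the same oxygen; the gap between compound 1 and compound 3 points the same way. A downward step beyond the scatter is therefore expected, an at least 2.0-fold lower number from compound 1 to compound 4 (0.30 log units; that floor lies within the scatter). Compound 4 is estimated at 100000 nM, with a range from 30000 nM to 200000 nM.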

Compound 4, half-maximal cytotoxic concentration: > 200000 nM
Compound 4: a limit, no number; the forecaster's own chance of this, stated with the estimate: 30%; at least 2.0-fold (0.30 log units) between middle value and limit.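

Compound 1 and compound 4 both sit at a limit rather than a number in this assay, so the step between them cannot be read: the limit of > 200000 nM in this assay, at which 2 of the 4 values shown sit.

The compounds shown leave open whether benzoyl in place of methyl on that oxygen changes the tolerated concentration at all.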